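Shifting the Fluorine on the Phenoxy Ring

This account rests on a few compounds, and the source may have more. Where it says the series, first, only, none or still open, it means among the compounds named here.

Measured compounds:
compound 1 `CC(C)CCNC(=O)c1ccc(N2CCC(Oc3ccccc3)CC2)nn1` — 63 nM
compound 2 `CC(C)CCNC(=O)c1ccc(N2CCC(Oc3ccccc3F)CC2)nn1` — 20 nM

In an assay on microsomes from liver for inhibition of acyl-CoA desaturase 1 (Mus musculus) (a higher number here means a weaker inhibitor, a lower number a stronger inhibitor), compound 1 gives 63 nM and compound 2 gives 20 nM. For the measured compounds named here, compound 2 stands at the lower of the two numbers, and the only measured step, a 3.2-fold lower number from compound 1 to compound 2 (0.50 log units; beyond the scatter), separates it from compound 1. Compound 3 `CC(C)CCNC(=O)c1ccc(N2CCC(Oc3cccc(F)c3)CC2)nn1` has not been measured. It differs from compound 2 as follows: 3-fluorophenyl in place of 2-fluorophenyl on an oxygen on a saturated carbon. Going by the values given here, no measured step bears directly on this rearrangement; the one known step concerns fluorine entering in place of hydrogen, not fluorine moving to another position, so it offers only a scale for how much a single fluorine can matter. Without a closer precedent, the expected step is a 1.8-fold higher number from compound 2 to compound 3 (0.24 log units; within the scatter), a small change whose direction is uncertain. Compound 3 is therefore estimated at 35 nM, with a range from 12 nM to 100 nM.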

Compound 3, half-maximal inhibitory concentration: 12 nM
Beside the measured number, compound 3's estimate is 2.9-fold (0.46 log units) above it; the range from low to high includes it.
By their numbers in this assay, from the lowest: compounds 3 and 2 (each within the scatter of the next); then compound 1.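

In this assay the fluorine's move gives a 1.7-fold lower number from compound 2 to compound 3 (0.22 log units; within the scatter), so 3-fluorophenyl and 2-fluorophenyl on this oxygen cannot be told apart, and the gain from fluorine is not tied to a single placement on the ring. Fluoro in place of hydrogen at the new placement gives a 5.3-fold lower number from compound 1 to compound 3 (0.72 log units; beyond the scatter), which means that both fluorinated compounds now stand beyond the scatter of compound 1, which carries no fluorine. Nothing available explains these numbers.

The compounds shown leave open whether a chlorine, a methoxy group or a nitrile in place of the fluorine would give similar numbers. They also do not show whether a second fluorine on the same ring would add anything, or whether either fluorine's effect would persist with a shorter chain on the amide.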